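Trifluoromethoxy for Cyano in a Sulfonamide Series

The source may hold more compounds than are shown below. What is called first, only, known or untested is meant among the compounds shown, and "the series" means these compounds.

Compound 1 `CC1CCN(C2CCN(S(=O)(=O)c3ccc(C#N)cc3)CC2)CC1` was tested in an ADME assay on HCT-116 cells (Homo sapiens) for cytotoxicity, read by CellTiter-Glo, with a stated time of 72 h; on this read-out lower numbers stand for stronger inhibition and higher numbers for weaker inhibition. In this assay compound 1 gives > 5000 nM, which is a limit of the assay rather than a number. Compound 2 `CC1CCN(C2CCN(S(=O)(=O)c3ccc(Cl)nc3)CC2)CC1` gives > 10000 nM in this assay, also a limit. Compound 3 `CC1CCN(C2CCN(S(=O)(=O)c3cccc(Br)c3)CC2)CC1` gives > 5000 nM in this assay, again a limit. The steps a step that the two limits leave unreadable from compound 1 to compound 2 and a step that the two limits leave unreadable from compound 1 to compound 3 cannot be read, because every value sits at a limit of > 10000 nM in this assay, at which 1 of the 3 values shown sits (the limit of > 5000 nM in this assay, at which 2 of the 3 values shown sit). Compound 4 `CC1CCN(C2CCN(S(=O)(=O)c3ccc(OC(F)(F)F)cc3)CC2)CC1` differs from compound 1 by trifluoromethoxy in place of cyano on an aromatic carbon. Going by the values given here, no measured step speaks readably to this change, so no direction can be drawn from the data. Compound 4 is therefore expected to sit at the limit as well, estimated at 8000 nM, with a range from 4000 nM to 20000 nM. The step this estimate means, a step that the limit leaves unreadable from compound 1 to compound 4, is expected to stay within the scatter.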

Compound 4, half-maximal inhibitory concentration: > 5000 nM
Compound 4 was reported as a limit (the forecaster's own chance of this, stated with the estimate: 85%); the middle value lies beyond the limit too.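

The step from compound 1 to compound 4 cannot be read, because both values in this assay are limits: the limit of > 5000 nM in this assay, at which 3 of the 4 values shown sit.

The compounds shown leave open how strongly any of them acts on these cells, and whether changing the group on the sulfonyl sulfur makes a real difference.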